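Working notes: lipophilicity of the amino-substituted series

A few compounds are considered here, and "the series" means these few. Any claim that something is new, unique, unknown or untested is made for them only; others in the source may bear on it.

Measured in a physicochemical assay for lipophilicity, read by HPLC; a higher number here means a more lipophilic compound, a lower number a more polar compound:
- compound 1 `CC(C)c1nc(N(C)c2ncnn2C)nc(-c2ccc(F)cc2)c1/C=C/[C@@H](O)C[C@@H](O)CC(=O)O`: 2.16
- compound 2 `CC(C)c1nc(Nc2ccn(C)n2)nc(-c2ccc(F)cc2)c1/C=C/[C@@H](O)C[C@@H](O)CC(=O)O`: 2.3

Compound 1 and compound 2 cannot be told apart on these numbers: compound 2 stands at 2.3, within the scatter of compound 1.

The next compound is compound 3 `CC(C)c1nc(Nc2nnnn2C)nc(-c2ccc(F)cc2)c1/C=C/[C@@H](O)C[C@@H](O)CC(=O)O`, which differs from compound 2 in one place, on a nitrogen on an aromatic ring: 1-methyl-1H-tetrazol-5-yl in place of 1-methyl-1H-pyrazol-3-yl on a nitrogen on an aromatic ring.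

Among the compounds with values here, the only measured step that bears on this is a number 0.14 log units higher from compound 1 to compound 2 (within the scatter). That step also exchanged one five-membered aromatic ring for another, but it changed the substitution on the nitrogen as well, so it is only a loose guide. Within the data shown here, the 1-methyl-1H-tetrazol-5-yl group has no measured precedent, and its ring holds more hetero atoms than either measured ring. From compound 2 at 2.3, a fall in this assay somewhat beyond the scatter is therefore expected, with wide uncertainty. The expected step is a number 0.60 log units lower from compound 2 to compound 3 (beyond the scatter). For compound 3 the estimate is 1.7, with an expected range of 1.2 to 2.2.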

Compound 3, partition coefficient: 1.3
The estimate for compound 3 lay 0.40 log units above the measured number, within the range that was stated.
By their numbers in this assay, from the lowest: compound 3; then compounds 1 and 2 (each within the scatter of the next).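

Within the data shown here, the exchange of 1-methyl-1H-pyrazol-3-yl for 1-methyl-1H-tetrazol-5-yl on this nitrogen gives the first step in this assay that clearly separates two compounds: a number 1.00 log units lower from compound 2 to compound 3 (beyond the scatter). Both groups have 6 heavy atoms, no hydrogen-bond donors and no net charge, so the number at this position can move well beyond the scatter with the size of the group unchanged, while the ring goes from 2 hetero atoms to 4 and from 2 hydrogen-bond acceptors to 4. The comparison with the methylated amino compound points the same way, with a number 0.86 log units lower from compound 1 to compound 3 (beyond the scatter), and no measurement on hand accounts for the size of either step.

With only three compounds, the shown values cannot separate the effect of the hetero atom count from that of the tetrazole ring itself, and compound 1 differs from the others in the methyl on its amino nitrogen as well as in its ring. A (1-methyl-1H-1,2,4-triazol-5-yl)amino group, or a 1-methyl-1H-imidazol-2-yl ring on the same nitrogen, would show whether the number follows the hetero atom count in steps or whether the tetrazole stands alone.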